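From methoxy to hydroxy on compound 2

The source may hold more compounds than are shown below. What is called first, only, known or untested is meant among the compounds shown, and "the series" means these compounds.

- compound 1 `N=C(N)c1ccc(-c2cc3cc(C(=N)N)cc(O)c3o2)c(O)c1` gives 2100 nM
- compound 2 `COc1cc(C(=N)N)ccc1-c1cc2cc(C(=N)N)ccc2o1` gives 157000 nM

In an ADME assay on L6 cells (Rattus norvegicus) for cytotoxicity (a higher number here means a weaker inhibitor, a lower number a stronger inhibitor), compound 2 stands highest of the two measured compounds (157000 nM), and compound 1 gives 2100 nM. That gap lies well beyond the scatter. Compound 3 (`N=C(N)c1ccc(-c2cc3cc(C(=N)N)ccc3o2)c(O)c1`) comes from compound 2 by a single change (hydrogen in place of methyl on an oxygen on an aromatic ring): hydrogen in place of methyl on an oxygen on an aromatic ring, or methoxy to hydroxy. Among the measured compounds shown here, no measured pair differs in one place only, so no earlier step sets the size of this one. The expectation rests on the gap alone, and compound 1 gives 2100 nM: the number for compound 3 is expected to fall from that of compound 2, by more than the scatter, yet to stay higher than that of compound 1. The expected move is a step (a 7.9-fold lower number from compound 2 to compound 3 (0.89 log units; beyond the scatter)). Compound 3 is estimated at 20000 nM within an expected range of 4000 nM to 100000 nM.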

Compound 3, half-maximal inhibitory concentration: 33300 nM
Compound 3: the middle estimate sits 1.7-fold (0.22 log units) below what was measured, within the range that was stated.
By their numbers in this assay, from the lowest: compound 1; then compound 3; then compound 2.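

In this assay the change from methoxy to hydroxy, with hydrogen in place of methyl on an oxygen on an aromatic ring, gives a 4.7-fold lower number from compound 2 to compound 3 (0.67 log units; beyond the scatter) and so provides the first single-place measure of this change. Hydrogen in place of hydroxy on an aromatic carbon gives a 16-fold higher number from compound 1 to compound 3 (1.20 log units; beyond the scatter) and is the larger of the two steps, so among these three compounds each hydroxy goes with a lower number and none goes against this. Nothing measured here explains either step.

The compounds leave open whether methoxy to hydroxy moves the number as far when the hydroxy of compound 1 is also present. They also leave open what an ethyl group on that oxygen, or an amine on that aromatic carbon, would do.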